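A few compounds are considered here, and "the series" means these few. Any claim that something is new, unique, unknown or untested is made for them only; others in the source may bear on it.

In an ADME assay on HEK293 cells (Homo sapiens) for cytotoxicity, read by MTT assay, with a stated time of 72 h (on this read-out higher numbers stand for weaker inhibition and lower numbers for stronger inhibition), compound 1 `O=C(CN1CCN(C(=O)c2ccccc2)CC1)N1CCN(CCCc2c[nH]c3ccccc23)CC1` reaches only a limit of the assay, > 200000 nM. Compound 2 `O=C(CN1CCN(C(=O)c2ccccc2)CC1)N1CCN(CCCc2c[nH]c3ccc(F)cc23)CC1` gives 148000 nM, the higher of the two exact numbers, while compound 3 `O=C(CN1CCN(C(=O)c2cccc(Br)c2)CC1)N1CCN(CCCc2c[nH]c3ccc(F)cc23)CC1` gives 40600 nM. Compound 4 `COc1ccc2[nH]cc(CCCN3CCN(C(=O)CN4CCN(C(=O)c5ccccc5)CC4)CC3)c2c1` differs from compound 2 in one place: methoxy in place of fluoro on an aromatic carbon. The closest evidence is an at least 1.3-fold lower number from compound 1 to compound 2 (0.13 log units; that floor lies within the scatter), seen with fluoro in place of hydrogen. The other step, a 3.6-fold lower number from compound 2 to compound 3 (0.56 log units; beyond the scatter), came with bromo in place of hydrogen, a different change, so it bears less directly. No step beyond the scatter is therefore expected in this assay, and the estimated change is a 1.1-fold lower number from compound 2 to compound 4 (0.02 log units; within the scatter). For compound 4 the estimated value is 140000 nM, with an expected range from 60000 nM to 300000 nM.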

Compound 4, half-maximal inhibitory concentration: > 200000 nM
Compound 4: a limit, no number; the forecaster's own chance of this, stated with the estimate: 30%; middle value at least 1.4-fold (0.15 log units) from the limit.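

In this assay, replacing 5-fluoro-1H-indol-3-yl with 5-methoxy-1H-indol-3-yl gives an at least 1.3-fold higher number from compound 2 to compound 4 (0.13 log units; that floor lies within the scatter), so this change shows no sign of stronger inhibition, although that floor stays within the scatter. The result for compound 4 is a limit, not a number. The step from compound 1 to compound 4 cannot be read, since both compounds sit at the same limit: the limit of > 200000 nM in this assay, at which 2 of the 4 values shown sit.

Going by these compounds, it remains open whether an amine or a carboxylic acid at this position would lower the number. Also open, on these data alone, is how methoxy behaves alongside the bromo of compound 3.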